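Ring amine exchange on the aromatic carbon: compound 3 to 4

The source may hold more compounds than are shown below. What is called first, only, known or untested is meant among the compounds shown, and "the series" means these compounds.

Compound 1 `O=C(Nc1cccc(Cl)c1)c1cc(C(F)(F)F)ccc1OCc1ccccc1` gives 25.1 nM in an assay on Sf9 cells for inhibition of Leucine-rich repeat serine/threonine-protein kinase 2 (Homo sapiens), read by TR-FRET, with stated times of 30 min and 2 h; a lower number here means a stronger inhibitor, a higher number a weaker inhibitor. Compound 2 `O=C(Nc1ccnnc1)c1cc(N2CCCC2)ccc1OCc1ccccc1` gives 20 nM in this assay, and compound 3 `C[C@@H]1CN(c2ccc(OCc3ccccc3)c(C(=O)Nc3ccnnc3)c2)C[C@H](C)O1` gives 20 nM in this assay. Compound 3 thus stands level with compound 2 at the digits shown, the two together the lowest of the three numbers, and compound 1 sits within the scatter of both. Within the data shown here, the only single-point step so far, no change at the digits printed from compound 2 to compound 3 (within the scatter), is flat. Compound 4 `O=C(Nc1ccnnc1)c1cc(N2CCC(CO)CC2)ccc1OCc1ccccc1` differs from compound 3 by a change of the same kind: 4-(hydroxymethyl)piperidin-1-yl in place of 2,6-dimethylmorpholin-4-yl on an aromatic carbon. Among the measured compounds shown here, only that flat step bears on it, so no shift beyond the scatter is expected in this assay. Compound 4 is expected at 20 nM, between 8 nM and 50 nM. The expected step is no change at the digits printed from compound 3 to compound 4 (within the scatter).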

Compound 4, half-maximal inhibitory concentration: 20 nM
Compound 4: the middle estimate sits on the measured number at the digits printed; the measured number falls inside the stated range.
By their numbers in this assay, from the lowest: compounds 2, 3, 4 and 1 (each within the scatter of the next).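

In this assay the place para to a benzyloxy group also takes 4-(hydroxymethyl)piperidin-1-yl, with no change at the digits printed from compound 3 to compound 4 (within the scatter) and no change at the digits printed from compound 2 to compound 4 (within the scatter) as its steps. A group with 1 hydrogen-bond donor and no defined stereocentres thus replaces one with 0 donors and 2 defined stereocentres, with no shift beyond the scatter. Nothing at hand explains this flatness.

Open, as far as these compounds go, is whether a carboxylic acid or a primary amine in place of the hydroxymethyl, or an open-chain diethylamino group on this carbon, would stay level. The compounds shown do not give the limits of this tolerance.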